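Formyl in place of phenyl on the shared core

A few compounds are considered here, and "the series" means these few. Any claim that something is new, unique, unknown or untested is made for them only; others in the source may bear on it.

For the measured compounds named here, compound 1 `Clc1ccc(N2CCN(Cc3cnn4c(-c5ccccc5)cccc34)CC2)cc1` has the lowest of the two numbers measured so far: in an assay on CHO cells for binding affinity to D(4) dopamine receptor (Homo sapiens) (on this read-out lower numbers stand for stronger inhibition and higher numbers for weaker inhibition), compound 1 gives 7.6 nM. Going by the values given here, compound 2 `Clc1ccc(N2CCN(Cc3cnn4c(N5CCN(Cc6ccccc6)CC5)cccc34)CC2)cc1` in this assay gives 180 nM, a higher number; the gap lies beyond the scatter, but the two structures differ in more than one place, so no single step connects them. Compound 3 `O=Cc1cccc2c(CN3CCN(c4ccc(Cl)cc4)CC3)cnn12` has not been measured. It differs from compound 1 by formyl in place of phenyl on an aromatic carbon. Among the compounds with values here, no step between measured compounds matches this change, so the expectation rests on the two numbers and the change itself: the group that leaves is a six-membered aromatic ring, the one that enters has no ring, and the only other departure from the phenyl of compound 1, seen in compound 2 with 180 nM, went to a weaker number. For compound 3 the expected step of a 7.9-fold higher number from compound 1 to compound 3 (0.90 log units; beyond the scatter) is an increase beyond the scatter. Compound 3 is estimated at 60 nM, with a range from 15 nM to 300 nM.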

Compound 3, inhibition constant: 2.6 nM
For compound 3 the middle estimate is 23-fold (1.36 log units) above the measured one; measured number outside the range, below it.
By their numbers in this assay, from the lowest: compound 3; then compound 1; then compound 2.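

On an aromatic carbon next to the ring nitrogen, formyl in place of phenyl gives a 2.9-fold lower number from compound 1 to compound 3 (0.47 log units; beyond the scatter) in this assay and so shows that the six-membered aromatic ring of compound 1 is not required at this position for a low number. For the compounds shown here, a group of 2 heavy atoms with no ring and 1 hydrogen-bond acceptor is tolerated here, something no single-place step among the earlier compounds could show. Nothing available accounts for the direction of this step.

Going by these compounds, it remains open whether the lower number goes with the carbonyl itself or only with the loss of the phenyl ring. A methyl, hydroxymethyl or carboxylic acid in the same place would separate these readings, and a primary amide or nitrile would test how far the carbonyl can be replaced.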